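Varying the Sulfonyl Aryl Group on a Shared Core

This account rests on a few compounds, and the source may have more. Where it says the series, first, only, none or still open, it means among the compounds named here.

Compound 1 `O=S(=O)(Nc1ccc2oc(-c3ccccc3)nc2c1)c1ccccc1F`: in an assay on cells for inhibition of HSP60/HSP10 (Homo sapiens), with a stated time of 60 min (a higher number here means a weaker inhibitor, a lower number a stronger inhibitor), compound 1 reaches only the assay limit > 100000 nM.
Compound 2 `O=S(=O)(Nc1ccc2oc(-c3ccccc3)nc2c1)c1cccc(O)c1`: in this assay compound 2 gives 76000 nM.
Compound 3 `O=S(=O)(Nc1ccc2oc(-c3ccccc3)nc2c1)c1cccs1`: in this assay compound 3 gives 90000 nM.

Compound 3 holds the higher of the two numbers; its nearest neighbour is compound 2, and the step of a 1.2-fold higher number from compound 2 to compound 3 (0.07 log units; within the scatter) lies within the scatter. Compound 1 sits at a limit, as told by the limit of > 100000 nM in this assay, at which 1 of the 3 values shown sits. Compound 4 `O=S(=O)(Nc1ccc2oc(-c3ccccc3)nc2c1)c1ccc(Cl)c(Cl)c1` differs from compound 3 by 3,4-dichlorophenyl in place of thiophen-2-yl on a sulfonyl sulfur. For the measured compounds named here, the steps that bear on this change, an at least 1.3-fold lower number from compound 1 to compound 2 (0.11 log units; that floor lies within the scatter) and an at least 1.1-fold lower number from compound 1 to compound 3 (0.04 log units; that floor lies within the scatter), swap the same group on the sulfonyl sulfur, and neither clears the scatter. A small step of a 1.5-fold lower number from compound 3 to compound 4 (0.18 log units; within the scatter) is therefore expected. Compound 4 is estimated at 60000 nM, with a range from 20000 nM to 200000 nM.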

Compound 4, half-maximal inhibitory concentration: > 100000 nM
Compound 4 ended at the assay's limit (the forecaster's own chance of this, stated with the estimate: 35%); middle value at least 1.6-fold (0.22 log units) away from the limit.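

In this assay, compound 4, with 3,4-dichlorophenyl on the sulfonyl sulfur, gives only the limit > 100000 nM. The readable steps, an at least 1.1-fold higher number from compound 3 to compound 4 (0.04 log units; that floor lies within the scatter) and an at least 1.3-fold higher number from compound 2 to compound 4 (0.11 log units; that floor lies within the scatter), give only floors within the scatter, so even this larger ring with two chlorines shows no clear shift from the thiophen-2-yl or 3-hydroxyphenyl groups. The step between compound 1 and compound 4 cannot be read: the limit of > 100000 nM in this assay, at which 2 of the 4 values shown sit.

On these data alone, how far compound 4 truly lies from compound 2 and compound 3 remains open. So does whether an amine or a carboxylic acid on this ring would give a clearly lower number.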